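This account rests on a few compounds, and the source may have more. Where it says the series, first, only, none or still open, it means among the compounds named here.

The measured compounds:

Compound 1, `COc1cc(-c2nn(-c3cccc(NC(=O)c4ccc(Cl)c(C(F)(F)F)c4)c3)cc2-c2ccncc2)ccc1Cl`, gives a limit of the assay in a functional assay on PC-3 cells (Homo sapiens) for inhibition, read by sulforhodamine B assay, with a stated time of 48 h (a lower number here means a stronger inhibitor of growth, a higher number a weaker inhibitor of growth), > 32500 nM.

Compound 2, `COc1cc(-c2nn(-c3cccc(NC(=O)c4cccc(C(F)(F)F)c4)c3)cc2-c2ccncc2)ccc1Cl`, gives a limit of the assay in this assay, > 50000 nM.

Compound 3, `O=C(Nc1cccc(-n2cc(-c3ccncc3)c(-c3ccc(Cl)c(O)c3)n2)c1)Nc1cc(C(F)(F)F)cc(C(F)(F)F)c1`, gives 4370 nM in this assay.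

For the measured compounds named here, compound 3 is thus the only compound with a real number in this assay; the other two values are limits rather than numbers, so compound 3 cannot be placed in order against them. Going by the values given here, the single step between measured compounds, a step that the two limits leave unreadable from compound 1 to compound 2, runs between two limits, and its size cannot be read.

Compound 4, `O=C(Nc1cccc(-n2cc(-c3ccncc3)c(-c3ccc(Cl)c(O)c3)n2)c1)Nc1cccc(C(F)(F)F)c1`, differs from compound 3 by hydrogen in place of trifluoromethyl on an aromatic carbon. Among the compounds with values here, no measured step covers the same change: the step from compound 1 to compound 2 removes a chloro rather than a trifluoromethyl, and its size is hidden by the two limits. With no readable precedent, the change is expected to shift this assay only modestly, if at all toward a weaker inhibitor of growth, and the result could sit anywhere within a broad band. Compound 4 is therefore estimated at 8000 nM, between 2500 nM and 30000 nM, an expected step of a 1.8-fold higher number from compound 3 to compound 4 (0.26 log units; within the scatter).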

Compound 4, concentration for total growth inhibition: 22500 nM
Compound 4: the middle estimate sits 2.8-fold (0.45 log units) below what was measured, and the stated range covers the measured number.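

Replacing trifluoromethyl with hydrogen at this spot, on an aromatic carbon meta to a large group and meta to a second trifluoromethyl group, gives a 5.1-fold higher number from compound 3 to compound 4 (0.71 log units; beyond the scatter) in this assay. For the compounds shown here, this is the first step in the set whose size can be read, since both values in the step between compound 1 and compound 2 are limits, and it shows that the trifluoromethyl group at this position matters: the compound that keeps it is the stronger inhibitor of growth of the pair. The compounds shown offer no measurement that explains why the number moves.

Going by these compounds alone, it remains open whether trifluoromethyl is the only group that holds the number near that of compound 3 at this spot, or whether a methyl group, a nitrile or an amine would do the same. Also open, as far as these compounds go, is whether removing a trifluoromethyl group would have a similar effect on the core of compound 1, whose value is only a limit.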